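This account rests on a few compounds, and the source may have more. Where it says the series, first, only, none or still open, it means among the compounds named here.

Working notes on the series. Compound 1 `COc1ccc2nc(C)cc(OCC(=O)Nc3cc(C)cc(C)c3)c2c1` is measured in an ADME assay on blood (Mus musculus, strain CD1) for pharmacokinetics, read by LC-MS, with a stated time of 240 min, tested at 0.5 uM (a lower number here means that the compound disappears faster, a higher number that the compound lasts longer), where it returns only a limit, < 0.0834 h. Compound 2 `Cc1cc(C)cc(NC(=O)COc2cc(C)nc3ccc(C)cc23)c1`, which carries methyl in place of methoxy on an aromatic carbon, likewise returns only a limit in this assay, < 0.0834 h. The step from compound 1 to compound 2 is therefore a step that the two limits leave unreadable from compound 1 to compound 2, both values resting at the limit of < 0.0834 h in this assay, at which 2 of the 3 values shown sit. For the measured compounds named here, compound 3 `COc1ccc2nc(C)cc(OCCNc3cc(C)cc(C)c3)c2c1` is the one member that sits at the other limit, > 2 h; it differs from compound 1 in the linker, no step being worked out for that pair, so only its value at the limit of > 2 h in this assay, at which 1 of the 3 values shown sits, is noted.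

Compound 4 `COc1ccc2nc(C)cc(OCC(=O)Nc3cc(C)c(F)c(C)c3)c2c1` is not yet measured; its change from compound 1 is fluoro in place of hydrogen on an aromatic carbon, that is, 3,5-dimethylphenyl to 4-fluoro-3,5-dimethylphenyl. Going by the values given here, no measured step touches the aromatic ring that carries the two methyl groups, and the one step nearby is unreadable. Compound 1 stands at a limit, so no direction can be read from it. The expected step from compound 1 to compound 4 in this assay is an at least 1.1-fold higher number from compound 1 to compound 4 (0.07 log units; that floor lies within the scatter), with most of the chance that the readout is again only a limit. Compound 4 is therefore estimated at 0.1 h, expected between 0.03 h and 0.4 h.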

Compound 4, half-life: < 0.0834 h
Compound 4: no number, only a limit; the forecaster's own chance of this, stated with the estimate: 60%; middle value at least 1.1-fold (0.07 log units) away from the limit.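

Compound 4 returns only a limit in this assay, < 0.0834 h. The step between compound 1 and compound 4 cannot be read, as both values rest at a limit: the limit of < 0.0834 h in this assay, at which 3 of the 4 values shown sit.

The compounds shown leave open whether fluoro in place of hydrogen changes the half-life at all.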